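Dichloro core with oxazole in place of pyrazole

The source may report more compounds than this note shows. Statements on the series, on what has been measured and on what is new or still open speak of the compounds shown alone.

Of the compounds shown here, two have been measured in an assay on cells for inhibition of histone-lysine N-methyltransferase EZH2 (Homo sapiens), read by ELISA, with a stated time of 72 h; a higher number here means a weaker inhibitor, a lower number a stronger inhibitor. Compound 1 `Cc1cc(C)c(CN2CCc3ccc(-c4c(C)noc4C)c(Cl)c3C2=O)c(=O)[nH]1` carries a single chloro group on its core and gives 105 nM. Compound 2 `Cc1cc(C)c(CN2CCc3c(Cl)cc(-c4c(C)n[nH]c4C)c(Cl)c3C2=O)c(=O)[nH]1` carries two chloro groups and the pyrazole and gives 502 nM, the higher of the two numbers; the gap to compound 1 lies beyond the usual scatter. The two differ in more than one place, so no single change can be read from them.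

Compound 3 `Cc1cc(C)c(CN2CCc3c(Cl)cc(-c4c(C)noc4C)c(Cl)c3C2=O)c(=O)[nH]1` differs from compound 2 in one place: 3,5-dimethyl-1,2-oxazol-4-yl in place of 3,5-dimethyl-1H-pyrazol-4-yl on an aromatic carbon. Compound 3 thus combines the aryl group of compound 1 with the core of compound 2. Among the measured compounds shown here, no measured pair isolates this exchange, so the direction rests on the values of compound 1 at 105 nM and compound 2 at 502 nM alone. The expected step from compound 2 to compound 3 is a modest move toward a lower number, a 2.3-fold lower number from compound 2 to compound 3 (0.36 log units; beyond the scatter), with a real chance of no change beyond the scatter. The estimate for compound 3 in this assay is 220 nM, within a range of 70 nM to 700 nM.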

Compound 3, half-maximal inhibitory concentration: 15 nM
Estimate against measurement, compound 3: 15-fold (1.17 log units) above, outside the stated range (below it).
By their numbers in this assay, from the lowest: compound 3; then compound 1; then compound 2.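

Among the compounds shown here, on the core of compound 2, in this assay, 3,5-dimethyl-1,2-oxazol-4-yl in place of 3,5-dimethyl-1H-pyrazol-4-yl, on the aromatic carbon ortho to a chloro group, gives a 33-fold lower number from compound 2 to compound 3 (1.52 log units; beyond the scatter), which is the first reading of this exchange in a single place, and the step is large. With 3,5-dimethyl-1,2-oxazol-4-yl held constant, chloro in place of hydrogen on an aromatic carbon gives a 7.0-fold lower number from compound 1 to compound 3 (0.85 log units; beyond the scatter), a modest step, so both single changes run the same way and compound 3 has the lowest number of the three. No measurement at hand says why either step has its size.

Open, from the compounds shown here alone, is whether the exchange gives a step of this size on the core of compound 1, and whether the chloro step holds with 3,5-dimethyl-1H-pyrazol-4-yl in place. Also open, going by these compounds, is how a plain phenyl ring, a pyridine ring, or an ethyl group in place of one ring methyl would read at this aromatic carbon in this assay.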